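Carboxy on the pyrrolidine ring of a chemokine receptor antagonist

A few compounds are considered here, and "the series" means these few. Any claim that something is new, unique, unknown or untested is made for them only; others in the source may bear on it.

Compound 1 `Cc1nn([C@H](C)c2ccc(Cl)cc2Cl)c2nc(N3CC[C@H](N4CCCC4)[C@H](C)C3)cnc12`: in a functional assay on cells for antagonist activity at C-C chemokine receptor type 4 (Homo sapiens), read by fluorescence and calcium flux, with stated times of 2.5 s and 45 s (a lower number here means a stronger inhibitor, a higher number a weaker inhibitor), compound 1 gives 69 nM.
Compound 2 `C[C@@H]1CC(c2cnc3c(C#N)nn([C@H](C)c4ccc(Cl)cc4Cl)c3n2)=CC[C@@H]1N1CCC[C@H]1CO`: in this assay compound 2 gives 40 nM.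

Compound 1 has the higher of the two numbers, yet its gap to compound 2 lies within the usual scatter, so the two cannot be ranked. Compound 3 `Cc1nn([C@H](C)c2ccc(Cl)cc2Cl)c2nc(N3CC[C@H](N4CCC[C@H]4C(=O)O)[C@H](C)C3)cnc12` differs from compound 1 in one place: carboxy in place of hydrogen on a saturated ring carbon. Among the compounds with values here, no measured pair shows this change, so the size of the step is open. The step from compound 1 to compound 3 is expected to be small, not clearly beyond the scatter in either direction, a 1.4-fold higher number from compound 1 to compound 3 (0.16 log units; within the scatter). Compound 3 is estimated at 100 nM, with a range from 30 nM to 400 nM.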

Compound 3, half-maximal inhibitory concentration: 670 nM
Estimate against measurement, compound 3: 6.7-fold (0.83 log units) below, outside the stated range (above it).
By their numbers in this assay, from the lowest: compounds 2 and 1 (each within the scatter of the next); then compound 3.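

Compound 1 and compound 2 differ in more than one place, so neither says what this ring carbon tolerates. In this assay the change from pyrrolidin-1-yl to 2-carboxypyrrolidin-1-yl now gives a 9.7-fold higher number from compound 1 to compound 3 (0.99 log units; beyond the scatter) as a step toward weaker inhibition, showing that a carboxy group on this saturated ring carbon, next to the ring nitrogen, is not tolerated as freely as hydrogen. Nothing available here gives a measured reason for this weakening.

On these data alone, whether a methyl ester or a primary amide on the same carbon would give a similar step remains open.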